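A few compounds are considered here, and "the series" means these few. Any claim that something is new, unique, unknown or untested is made for them only; others in the source may bear on it.

Series notes. Of the compounds shown here, three of the shared core have numbers so far, and none of them gives a strong inhibition number. In a functional assay (aorta) with Rattus norvegicus as the target (a higher number here means a weaker inhibitor, a lower number a stronger inhibitor), compound 1 `COC(=O)c1cc2ccccc2n1[C@@H]1c2cc(C#N)ccc2OC(C)(C)[C@H]1O` gives 33000 nM. Compound 2 `CCOC(=O)CCCN(c1ccccc1)[C@H]1c2cc(C#N)ccc2OC(C)(C)[C@@H]1O` returns in this assay only a limit of the assay, > 30000 nM. Compound 3 `CCOC(=O)CN(c1ccc(Cl)cc1)[C@H]1c2cc(C#N)ccc2OC(C)(C)[C@@H]1O` likewise gives in this assay only a limit, > 30000 nM, and not a number. Where compound 3 stands is therefore fixed by the limit of > 30000 nM in this assay, at which 2 of the 3 values shown sit; no step between two measured compounds can be read from the three values, and no direction of change is on hand for any alteration of the group on the amine nitrogen.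

The next compound, compound 4 `CCOC(=O)CN(c1nc2ccccc2o1)[C@H]1c2cc(C#N)ccc2OC(C)(C)[C@@H]1O`, differs from compound 3 in one place: 1,3-benzoxazol-2-yl in place of 4-chlorophenyl on an amine nitrogen. Going by the values given here, nothing among the measured compounds separates the effect of that group from the rest of the molecule, so no change beyond the scatter is expected in either direction. Compound 4 is expected to stay at about the level of its parent, the step estimated as a number no higher from compound 3 to compound 4 (the limit leaves the size open). Compound 4 is estimated at 30000 nM in this assay, within 8000 nM to 100000 nM, with a fair chance that only a limit is returned again.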

Compound 4, half-maximal inhibitory concentration: > 30000 nM
Compound 4: a limit, no number; the forecaster's own chance of this, stated with the estimate: 60%; the middle value sits exactly at the limit.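

Compound 4 also returns only a limit in this assay, > 30000 nM. Going by these compounds alone, compound 3 stands at a limit as well, so no step between compound 3 and compound 4 can be read. The compounds shown leave open whether 1,3-benzoxazol-2-yl and 4-chlorophenyl on the amine nitrogen differ at all, with most values held at one limit: the limit of > 30000 nM in this assay, at which 3 of the 4 values shown sit.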